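Methoxymethyl at the chain carbon of the quinoline carboxamide series

The source may report more compounds than this note shows. Statements on the series, on what has been measured and on what is new or still open speak of the compounds shown alone.

Measured compounds:
- compound 1 `Cc1nc2ccccc2c(-c2ccccc2)c1C(=O)N(C)Cc1cc(C(F)(F)F)cc(C(F)(F)F)c1`: 3.1 nM
- compound 2 `O=C(NCc1cc(C(F)(F)F)cc(C(F)(F)F)c1)c1c(CCl)nc2ccccc2c1-c1ccccc1`: 26 nM
- compound 3 `O=C(NCc1cc(C(F)(F)F)cc(C(F)(F)F)c1)c1c(CBr)nc2ccccc2c1-c1ccccc1`: 0.01 nM

In an in vitro assay on UC11MG cells for binding affinity to Substance-P receptor (Homo sapiens), read by radioligand binding (a lower number here means a stronger inhibitor, a higher number a weaker inhibitor), compound 1 gives 3.1 nM, the second highest of the three numbers; compound 2, at 26 nM, sits nearest to it, and compound 3, at 0.01 nM, is furthest from it. Compound 2 and compound 3 differ from compound 1 in more than one place, so their values are only read as they stand.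

Compound 4 `COCc1nc2ccccc2c(-c2ccccc2)c1C(=O)N(C)Cc1cc(C(F)(F)F)cc(C(F)(F)F)c1` differs from compound 1 by methoxy in place of hydrogen on a saturated chain carbon bound to an aromatic carbon. Among the compounds with values here, the only measured step at that place is a 2600-fold lower number from compound 2 to compound 3 (3.41 log units; beyond the scatter), which shows that this chain carbon tolerates change and can move the number strongly, but that step swaps one halogen for another and gives no direct guide for a methoxy entering in place of hydrogen. Within the data shown here, no other measured pair bears on the change. Among the measured compounds shown here, with this sensitivity noted but no matching precedent, the expectation in this assay is a step of a 1.2-fold lower number from compound 1 to compound 4 (0.09 log units; within the scatter), within the scatter. Compound 4 is estimated at 2.5 nM, with a range from 0.6 nM to 10 nM.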

Compound 4, half-maximal inhibitory concentration: 11 nM
For compound 4 the middle estimate is 4.4-fold (0.64 log units) below the measured one; the whole stated range lies below it.
By their numbers in this assay, from the lowest: compound 3; then compound 1; then compound 4; then compound 2.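

In this assay, within the data shown here, the step from methyl to methoxymethyl gives the first direct reading of a group entering at this saturated chain carbon: a 3.5-fold higher number from compound 1 to compound 4 (0.55 log units; beyond the scatter), a modest weakening beyond the scatter. Compound 4 still reads 11 nM, so the longer methoxymethyl chain is tolerated at a modest cost, a far smaller shift than the halogen exchange, a 2600-fold lower number from compound 2 to compound 3 (3.41 log units; beyond the scatter). Nothing at hand gives a reason for the weakening.

Open, from the compounds shown here alone, is whether the shift follows from the oxygen or from chain length alone, a question an ethyl at this carbon would address, while a hydroxymethyl or an aminomethyl would extend the reading to other groups. Also open, going by these compounds, is whether the methoxy step would carry over to the amide form that compound 2 and compound 3 share.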